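The source may hold more compounds than are shown below. What is called first, only, known or untested is meant among the compounds shown, and "the series" means these compounds.

Measured in a functional assay on MCF7 cells (Homo sapiens) for cytotoxicity, read by MTT assay, with a stated time of 96 h; a lower number here means a stronger inhibitor, a higher number a weaker inhibitor:
- compound 1 `COc1cc(C(=O)c2cn(-c3ccc(C)cc3)cc2-c2ccccc2[N+](=O)[O-])cc(OC)c1OC`: 65 nM
- compound 2 `COc1cc(C(=O)c2cn(-c3ccc(C)cc3)cc2-c2cccc(N)c2)cc(OC)c1OC`: 53 nM

Compound 2, at 53 nM, lies within the scatter of compound 1, so these two compounds cannot be ranked. The next compound is compound 3 `COc1cc(C(=O)c2cn(-c3ccc(N)cc3)cc2-c2cccc(N)c2)cc(OC)c1OC`, which differs from compound 2 as follows: amino in place of methyl on an aromatic carbon. Put another way, the 4-methylphenyl group of compound 2 becomes a 4-aminophenyl group in compound 3. Going by the values given here, the only measured step, a 1.2-fold lower number from compound 1 to compound 2 (0.09 log units; within the scatter), lies within the scatter and concerns a different substituent, so it bears on this exchange only indirectly. No measurement covers the exchange itself, and no step beyond the scatter is expected in this assay, in either direction. The estimate amounts to a 1.3-fold lower number from compound 2 to compound 3 (0.12 log units; within the scatter), an expected change that remains uncertain. For compound 3 the expected value is 40 nM, with an estimated range from 12 nM to 130 nM.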

Compound 3, half-maximal inhibitory concentration: 78 nM
Compound 3: the middle estimate sits 2.0-fold (0.29 log units) below what was measured; the measured number falls inside the stated range.
By their numbers in this assay, from the lowest: compounds 2, 1 and 3 (each within the scatter of the next).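

In this assay, going by these compounds alone, the exchange of methyl for amino on this ring gives a 1.5-fold higher number from compound 2 to compound 3 (0.17 log units; within the scatter), and this is the first measured change at this place, para to a large group. The step lies within the scatter, so 4-methylphenyl and 4-aminophenyl cannot be told apart here, although amino, unlike methyl, is counted as a hydrogen-bond donor and acceptor. Nothing available bears on how this exchange acts.

The compounds shown do not say whether a hydroxyl, a dimethylamino, a carboxylic acid or a longer chain at this place would give a step beyond the scatter. They also leave open whether the same exchange reads alike with the 2-nitrophenyl group of compound 1 in place of the 3-aminophenyl group.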